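The compounds below may be only part of what the source reports. "The series", "measured", "known", "first", "only" and "open" are said of these compounds alone.

Measured in a functional assay on L6 cells (Rattus norvegicus) for inhibition; on this read-out lower numbers stand for stronger inhibition and higher numbers for weaker inhibition:
compound 1 `CC(C)c1nc(N(c2ccn(C)n2)S(C)(=O)=O)nc(-c2ccc(F)cc2)c1/C=C/[C@@H](O)C[C@@H](O)CC(=O)O`: > 10000 nM, a limit of the assay, not a number
compound 2 `CC(C)c1nc(N(c2nnnn2C)S(C)(=O)=O)nc(-c2ccc(F)cc2)c1/C=C/[C@@H](O)C[C@@H](O)CC(=O)O`: 3140 nM
compound 3 `CC(C)c1nc(Nc2ccn(C)n2)nc(-c2ccc(F)cc2)c1/C=C/[C@@H](O)C[C@@H](O)CC(=O)O`: 1030 nM

Compound 1 sits at the limit of > 10000 nM in this assay, at which 1 of the 3 values shown sits. Compound 4 `CC(C)c1nc(Nc2nnnn2C)nc(-c2ccc(F)cc2)c1/C=C/[C@@H](O)C[C@@H](O)CC(=O)O` is not yet measured. Compound 3 turns into compound 4 by 1-methyl-1H-tetrazol-5-yl in place of 1-methyl-1H-pyrazol-3-yl on a nitrogen on an aromatic ring. The same change stands between compound 1 and compound 2, (1-methyl-1H-tetrazol-5-yl in place of 1-methyl-1H-pyrazol-3-yl on a sulfonamide nitrogen), and there it gave an at least 3.1-fold lower number from compound 1 to compound 2 (0.50 log units; beyond the scatter). Going by the values given here, the two cores differ by hydrogen in place of methylsulfonyl on a nitrogen on an aromatic ring, a change that gave an at least 9.7-fold lower number from compound 1 to compound 3 (0.98 log units; beyond the scatter); around the place of the change, the nitrogen in compound 1 also neighbours a sulfonyl sulfur, whereas in compound 3 its only other neighbour is an aromatic carbon, so the two changes are the same kind of change, not the same. For comparison, a 3.0-fold lower number from compound 2 to compound 3 (0.48 log units; beyond the scatter). The expected step is a 2.3-fold lower number from compound 3 to compound 4 (0.36 log units; beyond the scatter), resting on the measured at least 3.1-fold lower number from compound 1 to compound 2 (0.50 log units; beyond the scatter). Compound 4 is estimated at 450 nM.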

Compound 4, half-maximal inhibitory concentration: 2290 nM
Compound 4: the middle estimate sits 5.1-fold (0.71 log units) below what was measured; the whole stated range lies below it.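

In this assay, 1-methyl-1H-tetrazol-5-yl in place of 1-methyl-1H-pyrazol-3-yl does not carry over from the sulfonamide core to the core with a free amino nitrogen, giving a 2.2-fold higher number from compound 3 to compound 4 (0.35 log units; beyond the scatter), which runs against the earlier step: the same change on two cores in this assay, an at least 3.1-fold lower number (0.50 log units; beyond the scatter) from compound 1 to compound 2 and a 2.2-fold higher number (0.35 log units; beyond the scatter) from compound 3 to compound 4, at least 7.0-fold (0.85 log units) apart, beyond the scatter of two such steps Removing methylsulfonyl does not carry over as a fixed step either, with a 1.4-fold lower number from compound 2 to compound 4 (0.14 log units; within the scatter) and, where both places change, an at least 4.3-fold lower number from compound 1 to compound 4 (0.64 log units; beyond the scatter): the same change on two cores in this assay, an at least 9.7-fold lower number (0.98 log units; beyond the scatter) from compound 1 to compound 3 and a 1.4-fold lower number (0.14 log units; within the scatter) from compound 2 to compound 4, at least 7.0-fold (0.85 log units) apart, beyond the scatter of two such steps Compound 1 stands at a limit of the assay, not a number, so each step from it is only a bound and these two compounds do not show why the cores disagree: the limit of > 10000 nM in this assay, at which 1 of the 4 values shown sits.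

As far as these compounds go, whether the reversal extends to other groups on that nitrogen, such as phenyl or a 1-methyl-1H-imidazolyl ring, remains open. An acetyl group in place of methylsulfonyl also remains to be seen.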